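A few compounds are considered here, and "the series" means these few. Any claim that something is new, unique, unknown or untested is made for them only; others in the source may bear on it.

Measured compounds in a functional assay on MIA cells (Homo sapiens) for inhibition, read by MTT assay, with a stated time of 72 h; on this read-out lower numbers stand for stronger inhibition of growth and higher numbers for weaker inhibition of growth:

- compound 1, `N#C/C(=C\c1c[nH]c2ccccc12)C(=O)c1c[nH]c2ccccc12`: 14000 nM
- compound 2, `N#C/C(=C\c1ccc[nH]1)C(=O)NCc1ccc(Cl)c(Cl)c1`: > 50000 nM, which is a limit of the assay and not a number
- compound 3, `COc1ccc(CNC(=O)/C(C#N)=C/c2ccco2)cc1`: 34000 nM

Of the two real numbers in this assay, compound 3 holds the higher one; compound 1 sits below it by a gap beyond the usual scatter, so compound 3 is the weaker of the two measured by a number. The third value, that of compound 2, is only a limit (the limit of > 50000 nM in this assay, at which 1 of the 3 values shown sits), so compound 3 cannot be placed against it.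

Compound 4, `COc1ccc(CNC(=O)/C(C#N)=C/c2cc(Br)co2)cc1`, is the next compound. It differs from compound 3 in one place: bromo in place of hydrogen on an aromatic carbon of the five-membered aromatic ring with 1 oxygen, two ring bonds from the ring oxygen. For the measured compounds named here, no pair of measured compounds in this assay shows such a step, and nothing among the three measured compounds speaks to what a bromine on that ring does. The change is small in size, and the expectation is a step of modest size at most, in either direction, likely within the scatter. Compound 4 is therefore estimated at 28000 nM, between 9000 nM and 60000 nM, in this assay. That estimate means a step from compound 3 to compound 4 of a 1.2-fold lower number from compound 3 to compound 4 (0.08 log units; within the scatter), expected to be small.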

Compound 4, concentration for 50% growth inhibition: 65000 nM
The estimate for compound 4 lay 2.3-fold (0.37 log units) below the measured number; measured number above the stated range.
By their numbers in this assay, from the lowest: compound 1; then compounds 3 and 4 (each within the scatter of the next).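

Bromo in place of hydrogen on an aromatic carbon of the five-membered aromatic ring with 1 oxygen, two ring bonds from the ring oxygen, is the one change that can be read in this assay, and it gives a 1.9-fold higher number from compound 3 to compound 4 (0.28 log units; within the scatter). Going from furan-2-yl to 4-bromofuran-2-yl therefore adds 1 heavy atom at this position without a difference that can be told from the scatter, so this single step shows neither a gain nor a loss in growth inhibition and puts no order on compound 3 and compound 4. Nothing shown bears on a cause for this step.

Bromo is the only group shown at this position, so it remains open whether an amine, a carboxylic acid or a longer chain there would give a step beyond the scatter, and whether bromo on another carbon of the same ring would read the same way. From the compounds shown here alone, compound 1 and compound 2 differ from compound 3 in more than one place, so the effect of this change on their cores also remains open.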